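Pyridinyl sulfonyl swap on the shared core: compound 3 to 4

A few compounds are considered here, and "the series" means these few. Any claim that something is new, unique, unknown or untested is made for them only; others in the source may bear on it.

The series shares one core carrying a sulfonyl group on the ring nitrogen, and the members differ only in the group on that sulfonyl sulfur. Compound 1 `CNCc1cn(S(=O)(=O)c2ccco2)c(-c2cccnc2F)c1F` carries furan-2-yl and in a functional assay on the whole organism (strain Jcl:Sprague-Dawley) for inhibition, with Rattus norvegicus as the target, with stated times of 3 min and 3 h, at a dose of 1 mg/kg by the intravenous route (on this read-out higher numbers stand for more inhibition at the one dose given (going by the name of the read-out) and lower numbers for less inhibition), compound 1 gives 75%. Compound 2 `CNCc1cn(S(=O)(=O)c2cc(OC)ccn2)c(-c2cccnc2F)c1F` carries 4-methoxypyridin-2-yl and in this assay compound 2 gives 95%; the change is a number 20 percentage points higher from compound 1 to compound 2 (beyond the scatter). Compound 3 `CNCc1cn(S(=O)(=O)c2cncc(Cl)c2)c(-c2cccnc2F)c1F` carries 5-chloropyridin-3-yl, but in this assay compound 3 gives "not determined" (no result reported), so no single number stands for it.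

Compound 4 `CNCc1cn(S(=O)(=O)c2cnccc2C)c(-c2cccnc2F)c1F` differs from compound 3 as follows: 4-methylpyridin-3-yl in place of 5-chloropyridin-3-yl on a sulfonyl sulfur. For the measured compounds named here, the only measured step at this same place, the one from compound 1 to compound 2, was modest and beyond the scatter, so a change of the group on the sulfonyl sulfur can move this assay noticeably. With no number for compound 3, nothing anchors the direction. Compound 4 is therefore expected to give about 80% in this assay, with an estimated range from 50% to 98%.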

Compound 4, a percentage reported as inhibition, in the whole organism at one dose (the size of the read-out at that dose, not a potency): 98%
Compound 4: the middle estimate sits 18 percentage points below what was measured, and the stated range covers the measured number.
By their numbers in this assay, from the lowest: compound 1; then compounds 2 and 4 (each within the scatter of the next).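

In this assay, replacing furan-2-yl with 4-methylpyridin-3-yl on the sulfonyl sulfur gives a number 23 percentage points higher from compound 1 to compound 4 (beyond the scatter), so a second pyridine-bearing group also stands clear of the furan-2-yl compound. Replacing 4-methoxypyridin-2-yl with 4-methylpyridin-3-yl gives a number 3 percentage points higher from compound 2 to compound 4 (within the scatter), showing that this read-out does not separate these two pyridine-bearing groups, although their names differ in both the substituent and the point of attachment. Nothing available here accounts for either step.

With a single dose and no potency, the compounds shown leave open whether any real difference between the two pyridine-bearing groups exists. They also leave open how a plain phenyl ring, a pyridine carrying a carboxylic acid, or a saturated amine such as piperidine would fare on the sulfonyl sulfur.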